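From chloro to fluoro: a small swap, little evidence

The source may hold more compounds than are shown below. What is called first, only, known or untested is meant among the compounds shown, and "the series" means these compounds.

Measured so far in a functional assay on HCT-116 cells (Homo sapiens) (on this read-out higher numbers stand for weaker inhibition of growth and lower numbers for stronger inhibition of growth), are three compounds
compound 1 `Oc1cc(-c2ccc(Cl)cc2)nc2ncccc12` gives 32400 nM
compound 2 `COc1cccc(-c2cc(=O)c3ccc(C)nc3[nH]2)c1` gives 46.8 nM
compound 3 `Cc1cnc2nc(-c3ccc(Cl)cc3)cc(O)c2c1` gives 2820 nM

Compound 3 has the second highest of these three numbers, with compound 1 higher and compound 2 much lower, and both gaps lie beyond the scatter. The next compound to be tested is compound 4 `Cc1cnc2nc(-c3ccc(F)cc3)cc(O)c2c1`, which carries fluoro in place of chloro on an aromatic carbon, para to a large group (fluoro in place of chloro on an aromatic carbon).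

Among the compounds with values here, no measured pair shows this swap, so the data offer no direct guide. Within the data shown here, the only measured step between compounds that differ in one place is an 11-fold lower number from compound 1 to compound 3 (1.06 log units; beyond the scatter). It is large, but it puts methyl in place of hydrogen and involves neither chloro nor fluoro. Among the measured compounds shown here, it shows only that one small change can shift the number strongly here, which argues for a wide range. Compound 2 differs from compound 3 in more than one place, so it gives no clean comparison.

No step beyond the scatter is therefore expected in this assay, and the expected result is a 1.1-fold higher number from compound 3 to compound 4 (0.03 log units; within the scatter). For compound 4 the estimated value is 3000 nM, with an expected range from 800 nM to 11000 nM.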

Compound 4, concentration for 50% growth inhibition: 24000 nM
For compound 4 the middle estimate is 8.0-fold (0.90 log units) below the measured one, outside the stated range (above it).
By their numbers in this assay, from the lowest: compound 2; then compound 3; then compounds 4 and 1 (each within the scatter of the next).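

This position on the six-membered aromatic ring of carbon only, para to a large group, turns out to respond strongly to a very small change. In this assay the swap of chloro for fluoro gives an 8.5-fold higher number from compound 3 to compound 4 (0.93 log units; beyond the scatter) and means weaker inhibition of growth, even though one halogen atom simply replaces another and no ring, hydrogen-bond donor, hydrogen-bond acceptor or charge enters or leaves. The earlier step, an 11-fold lower number from compound 1 to compound 3 (1.06 log units; beyond the scatter), came from adding methyl elsewhere on the molecule, so there are now two separate places where a single small change moves the number beyond the scatter, but nothing measured here explains why this swap has the effect it does.

The compounds shown cover only chloro and fluoro at this position, so it remains open how a larger halogen such as bromo, or a different group such as nitrile or trifluoromethyl, would read out there. From the compounds shown here alone, it is also open whether the same swap would have a similar effect without the methyl that compound 3 and compound 4 share, and compound 2 differs from them in too many places to settle this.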